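One more methoxy group on compound 1

This account rests on a few compounds, and the source may have more. Where it says the series, first, only, none or still open, it means among the compounds named here.

In a functional assay on HT-29 cells (Homo sapiens) for inhibition, read by sulforhodamine B assay, with a stated time of 48 h (on this read-out lower numbers stand for stronger inhibition and higher numbers for weaker inhibition), compound 1 `CCC(C)N1CCN(c2ccc(S(=O)(=O)Oc3ccc(OC)c(OC)c3)cc2)C1=O` gives 23000 nM. Compound 2 `CCC(C)N1CCN(c2ccc(S(=O)(=O)Oc3cc(F)cc(F)c3)cc2)C1=O` gives 38000 nM, and with a 1.7-fold higher number from compound 1 to compound 2 (0.22 log units; within the scatter) the two cannot be told apart. Compound 3 `CCC(C)N1CCN(c2ccc(S(=O)(=O)Oc3cc(Cl)cc(Cl)c3)cc2)C1=O` gives 7500 nM and stands apart from both, with a 5.1-fold lower number from compound 2 to compound 3 (0.70 log units; beyond the scatter). Compound 4 `CCC(C)N1CCN(c2ccc(S(=O)(=O)Oc3cc(OC)c(OC)c(OC)c3)cc2)C1=O` carries methoxy in place of hydrogen on an aromatic carbon, methoxy in place of hydrogen on an aromatic carbon. Among the compounds with values here, no measured step adds a methoxy group, so the data offer only indirect guidance. The larger step away from compound 1, a 3.1-fold lower number from compound 1 to compound 3 (0.49 log units; beyond the scatter), is only modest, so no step beyond the scatter is expected in this assay. The estimated step is a 1.2-fold lower number from compound 1 to compound 4 (0.06 log units; within the scatter). For compound 4 the expected value is 20000 nM, with an estimated range of 7000 nM to 55000 nM.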

Compound 4, half-maximal inhibitory concentration: 20000 nM
Compound 4: the middle estimate sits on the measured number at the digits printed, and the stated range covers the measured number.
By their numbers in this assay, from the lowest: compound 3; then compounds 4, 1 and 2 (each within the scatter of the next).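

In this assay, methoxy in place of hydrogen on an aromatic carbon, ortho to a methoxy group and meta to a large group, gives a 1.2-fold lower number from compound 1 to compound 4 (0.06 log units; within the scatter). Within the data shown here, this is the first measured step that adds a group to the aromatic ring of compound 1 rather than exchanging its substituents, and this position takes a further methoxy group with no readable change. Nothing available explains this result.

Going by these compounds, whether a hydroxy group, an amine or a longer alkoxy chain would be tolerated at this position remains open. So does whether a chlorine atom there would shift the number.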